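This account rests on a few compounds, and the source may have more. Where it says the series, first, only, none or still open, it means among the compounds named here.

Measured compounds:
compound 1 `C[C@@H](C#Cc1cccc(C(=O)NCc2ccccc2C(F)(F)F)c1)N(O)C(N)=O`: 700 nM
compound 2 `CC(C#Cc1cccc(C(=O)NCc2ccc(F)cc2C(F)(F)F)c1)N(O)C(N)=O`: 1300 nM
compound 3 `CC(C#Cc1cccc(C(=O)NCCC(c2ccccc2)c2ccc(C(F)(F)F)cc2)c1)N(O)C(N)=O`: 150 nM

In an assay for inhibition of Polyunsaturated fatty acid 5-lipoxygenase (Homo sapiens), read by HPLC, with stated times of 15 min and 10 min (a lower number here means a stronger inhibitor, a higher number a weaker inhibitor), compound 1 gives 700 nM, the second highest of the three numbers. Its nearest neighbour is compound 2, which gives 1300 nM in this assay; this pair lies within the scatter, so no order between them is claimed. The furthest is compound 3, which in this assay gives 150 nM, a number beyond the scatter from compound 1.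

Compound 4 `CCCC(C#Cc1cccc(C(=O)NCc2ccccc2C(F)(F)F)c1)N(O)C(N)=O` has not yet been measured. It differs from compound 1 in one place: 1-(carbamoyl(hydroxy)amino)butyl in place of 1-(carbamoyl(hydroxy)amino)ethyl on a triple-bonded carbon. No pair among the measured compounds has been compared along this kind of change, so there is no shown step to lean on; compound 3 differs from compound 1 elsewhere as well, and its value cannot be read as a guide for this change.

With nothing shown for this chain extension, the expectation for the step of a 1.2-fold lower number from compound 1 to compound 4 (0.07 log units; within the scatter) is a change not clearly beyond the scatter, in either direction. For compound 4 in this assay the estimate is 600 nM, with a range from 200 nM to 1800 nM.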

Compound 4, half-maximal inhibitory concentration: 300 nM
Estimate against measurement, compound 4: 2.0-fold (0.30 log units) above; the range from low to high includes it.
By their numbers in this assay, from the lowest: compounds 3 and 4 (each within the scatter of the next); then compounds 1 and 2 (each within the scatter of the next).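

In this assay, among these compounds, the earlier compounds offered no step at this position, and the first one now reads a 2.3-fold lower number from compound 1 to compound 4 (0.37 log units; beyond the scatter), a modest change, when 1-(carbamoyl(hydroxy)amino)butyl replaces 1-(carbamoyl(hydroxy)amino)ethyl on a triple-bonded carbon. The position therefore accepts the larger group, with 9 heavy atoms in place of 7 and the same counts of hydrogen-bond donors and acceptors, though the group that leaves has a defined stereocentre and the group that enters has none, so this single step does not separate chain length from stereochemistry. No measurement offered here accounts for the step.

As far as these compounds go, a single step sets no trend, so it remains open whether a longer chain such as pentyl, a branched group such as isopropyl or a small ring such as cyclopropyl would continue, hold or reverse the change. From the compounds shown here alone, it is also open how the separate stereoisomers of compound 4 compare, and whether the same chain extension gives a similar step on the fluorinated benzyl amide of compound 2.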